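A few compounds are considered here, and "the series" means these few. Any claim that something is new, unique, unknown or untested is made for them only; others in the source may bear on it.

Within the data shown here, compound 1 `CCCCCCCCCCCCCCCCO[C@H]1O[C@H](COCC(CO)(CO)COS(=O)(=O)O)[C@@H](O)[C@H](O)[C@H]1NC(=O)CCCC` is the only one of the three compounds with a number rather than a limit: in a functional assay on U-373MG ATCC cells (Homo sapiens), read by thymidine incorporation (a higher number here means a weaker inhibitor, a lower number a stronger inhibitor), compound 1 gives 3.2 uM. Compound 2 `CCCCC(=O)N[C@H]1[C@@H](OCCc2ccccc2)O[C@H](COCC(CO)(CO)CO)[C@@H](O)[C@@H]1O` sits at a limit of the assay, reporting > 50 uM in this assay. Compound 3 `CCCCC(=O)N[C@H]1[C@@H](OCCc2ccccc2)O[C@H](COCC(O)CO)[C@@H](O)[C@@H]1O` likewise sits at a limit, reporting > 50 uM. The step that the two limits leave unreadable from compound 2 to compound 3 therefore cannot be read, even though it brings in the same 1,2-dihydroxyethyl group that compound 4 `CCCCCCCCCCCCCCCCO[C@H]1O[C@H](COC[C@H](O)CO)[C@@H](O)[C@H](O)[C@H]1NC(=O)CCCC` carries. Compound 4 differs from compound 1 by 1,2-dihydroxyethyl in place of 2-hydroxy-1-(hydroxymethyl)-1-((sulfooxy)methyl)ethyl on a saturated chain carbon bound to an oxygen on a saturated carbon. No readable step covers this change, because the one comparable move is hidden by the limit of > 50 uM in this assay, at which 2 of the 3 values shown sit. A weakening step is nonetheless expected, a 4.7-fold higher number from compound 1 to compound 4 (0.67 log units; beyond the scatter). Compound 4 is therefore estimated at 15 uM, in a range from 3 uM to 50 uM.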

Compound 4, concentration for 50% inhibition: 4.9 uM
Compound 4: the middle estimate sits 3.1-fold (0.49 log units) above what was measured; the range from low to high includes it.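

In this assay, swapping the group at this position gives a 1.5-fold higher number from compound 1 to compound 4 (0.19 log units; within the scatter). Compound 1 and compound 4 therefore cannot be told apart here, so the 2-hydroxy-1-(hydroxymethyl)-1-((sulfooxy)methyl)ethyl group, with its sulfur, is not required for a measurable number on this core. The earlier compounds could not show this, because the step from compound 2 to compound 3, which brings in the same 1,2-dihydroxyethyl group, cannot be read: the limit of > 50 uM in this assay, at which 2 of the 4 values shown sit.

Still open, going by these compounds, is how an amine or a carboxylic acid at this place would read in this assay.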